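This account rests on a few compounds, and the source may have more. Where it says the series, first, only, none or still open, it means among the compounds named here.

In a functional assay on M14 cells (Homo sapiens) for inhibition, read by sulforhodamine B assay, with a stated time of 48 h, tested at 10 uM (a higher number here means a weaker effect of the compound at the concentration tested, a lower number a stronger effect), the three measured compounds are:

Compound 1, `COc1cc(Cl)cc(-c2nn(-c3cccc(NC(=O)Nc4cccc(C(F)(F)F)c4)c3)cc2-c2ccncc2)c1`, gives 9.99%.
Compound 2, `COc1cc(Cl)cc(-c2nn(-c3cccc(NC(=O)Nc4ccc(Cl)c(C(F)(F)F)c4)c3)cc2-c2ccncc2)c1`, gives 3.99%.
Compound 3, `COc1cc(Cl)cc(-c2nn(-c3cccc(NC(=O)c4cc(C(F)(F)F)cc(C(F)(F)F)c4)c3)cc2-c2ccncc2)c1`, gives 67.3%.

Compound 2 has the lowest number of the three, yet its nearest neighbour, compound 1, lies within the scatter: a number 6 percentage points lower from compound 1 to compound 2 (within the scatter). Compound 3 is the far one, its number standing beyond the scatter above compound 2, so those two can truly be told apart.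

Compound 4, `COc1cc(Cl)cc(-c2nn(-c3cccc(NC(=O)c4ccc(Cl)c(Cl)c4)c3)cc2-c2ccncc2)c1`, has not been measured. It differs from compound 2 in one place: 3,4-dichlorophenyl in place of (4-chloro-3-(trifluoromethyl)phenyl)amino on a carbonyl carbon. Among the measured compounds shown here, no measured one-place step matches this change. For the measured compounds named here, the only such step, a number 6 percentage points lower from compound 1 to compound 2 (within the scatter), concerns chloro in place of hydrogen on an aromatic carbon and stays within the scatter, so it says little here. Compound 3, though, likewise carries an aromatic ring directly on the carbonyl carbon rather than through an amino group, and its value is far higher than that of compound 2. On that resemblance a large upward step, toward a weaker effect, is expected, with wide uncertainty because compound 3 also differs from compound 4 in the groups on that ring. Compound 4 is therefore estimated at 50%, between 20% and 85%. The expected step is a number 46 percentage points higher from compound 2 to compound 4 (beyond the scatter).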

Compound 4, a percentage reported as activity, at one concentration (the size of the read-out at that concentration, not a potency): 68.9%
The estimate for compound 4 lay 18.9 percentage points below the measured number; the range from low to high includes it.
By their numbers in this assay, from the lowest: compounds 2 and 1 (each within the scatter of the next); then compounds 3 and 4 (each within the scatter of the next).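

The change at this carbonyl carbon matters greatly in this assay: with 3,4-dichlorophenyl in place of the arylamino groups, there is a number 64.9 percentage points higher from compound 2 to compound 4 (beyond the scatter) and a number 58.9 percentage points higher from compound 1 to compound 4 (beyond the scatter), so the effect at the tested concentration becomes much weaker. Unlike the earlier step from hydrogen to chloro on the aromatic ring, which stayed within the scatter, both of these steps lie far beyond it, and compound 3 at 67.3% and compound 4 at 68.9%, which both carry an aromatic ring directly on the carbonyl carbon, lie within the scatter of each other. No measurement here explains why the number rises so sharply.

The group that leaves differs from the one that enters in both its amino nitrogen, with its hydrogen-bond donor, and its trifluoromethyl group, so these compounds cannot show which difference carries the step. From the compounds shown here alone, a 3,4-dichlorophenylamino group on the same carbonyl carbon would help to separate the two, and it remains open whether a methylene link or an oxygen link in place of the amino nitrogen would keep the numbers low.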